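Furan for thiophene on a nucleoside core at the limit

The source may report more compounds than this note shows. Statements on the series, on what has been measured and on what is new or still open speak of the compounds shown alone.

Compound 1 `Nc1nc(N)c2c(-c3ccsc3)cn([C@@H]3O[C@H](CO)[C@@H](O)[C@H]3O)c2n1` is tested in a functional assay on HCT-116 cells (Homo sapiens), read by MTT assay, with a stated time of 72 h; a lower number here means a stronger inhibitor, a higher number a weaker inhibitor. In this assay compound 1 gives only a limit of the assay, > 20000 nM. Compound 2 `COc1ncnc2c1c(I)cn2[C@@H]1O[C@H](CO)[C@@H](O)[C@H]1O` likewise gives only a limit in this assay, > 20000 nM. Both results sit at the limit of > 20000 nM in this assay, at which 2 of the 2 values shown sit, so compound 1 stands at the limit with no number to rank it. Compound 3 `Nc1nc(N)c2c(-c3ccoc3)cn([C@@H]3O[C@H](CO)[C@@H](O)[C@H]3O)c2n1` differs from compound 1 by furan-3-yl in place of thiophen-3-yl on an aromatic carbon. For the measured compounds named here, no measured step exists for this change; no step beyond the scatter is expected here, a step that the limit leaves unreadable from compound 1 to compound 3. Compound 3 is therefore expected at 30000 nM in this assay, between 8000 nM and 120000 nM, most likely again reported only as a limit.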

Compound 3, half-maximal inhibitory concentration: > 20000 nM
Compound 3 was reported as a limit (the forecaster's own chance of this, stated with the estimate: 80%); the middle value lies beyond the limit too.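

For the compounds shown here, compound 3 gives only a limit, > 20000 nM, as does compound 1, and no step from compound 1 to compound 3 can be read. Going by these compounds, whether furan-3-yl and thiophen-3-yl differ in effect on the shared core stays open.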